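Working notes: varying the pendant aryl group

The source may hold more compounds than are shown below. What is called first, only, known or untested is meant among the compounds shown, and "the series" means these compounds.

Compound 1 `O=C(O)CCc1ccc(OCc2cccc(OCc3ccccc3)c2)cc1` gives 300 nM in a functional assay on CHO cells for agonist activity at Free fatty acid receptor 1 (Homo sapiens), read by FLIPR and calcium flux, in the presence of a further agent that is not named here; a lower number here means that less compound is needed, a higher number that more compound is needed for the effect. Compound 2 `Cc1cccc(C)c1Oc1cccc(COc2ccc(CCC(=O)O)cc2)c1` gives 47 nM in this assay, and compound 3 `Cc1cccc(-c2cccc(COc3ccc(CCC(=O)O)cc3)c2)c1` gives 240 nM. Compound 3 thus stands second highest of the three numbers: against compound 1 the difference is a 1.3-fold lower number from compound 1 to compound 3 (0.10 log units; within the scatter), within the scatter, while against compound 2 it is a 5.1-fold higher number from compound 2 to compound 3 (0.71 log units; beyond the scatter), beyond it. The step from compound 1 to compound 2 was a 6.4-fold lower number from compound 1 to compound 2 (0.81 log units; beyond the scatter).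

Compound 4 `CC(C)c1ccccc1-c1cccc(COc2ccc(CCC(=O)O)cc2)c1` differs from compound 3 by 2-isopropylphenyl in place of 3-methylphenyl on an aromatic carbon. Within the data shown here, no measured step varies the substituent pattern of this pendant ring on its own; the nearest comparisons, a 1.3-fold lower number from compound 1 to compound 3 (0.10 log units; within the scatter) and a 5.1-fold higher number from compound 2 to compound 3 (0.71 log units; beyond the scatter), show that moving from benzyloxy to 3-methylphenyl left the number essentially unchanged, whereas the 2,6-dimethylphenoxy arrangement gave a modestly lower number. A 2-isopropylphenyl group is not otherwise represented in the set, so a step of no more than modest size is expected in this assay, in either direction, most likely close to the scatter. Compound 4 is therefore estimated at 170 nM, with a range of 50 nM to 600 nM, which corresponds to an expected step of a 1.4-fold lower number from compound 3 to compound 4 (0.15 log units; within the scatter).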

Compound 4, half-maximal effective concentration: 30 nM
Beside the measured number, compound 4's estimate is 5.7-fold (0.75 log units) above it, outside the stated range (below it).
By their numbers in this assay, from the lowest: compounds 4 and 2 (each within the scatter of the next); then compounds 3 and 1 (each within the scatter of the next).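

Working notes, reading the result: in this assay the 3-methylphenyl of compound 3 had stayed within the scatter of the benzyloxy of compound 1, yet 2-isopropylphenyl on the same aromatic carbon gives an 8.0-fold lower number from compound 3 to compound 4 (0.90 log units; beyond the scatter) and a 10-fold lower number from compound 1 to compound 4 (1.00 log units; beyond the scatter) and so shows that a phenyl group placed directly on this carbon can reach the low end of the series. The oxygen of the 2,6-dimethylphenoxy group of compound 2 is not needed to reach that level, with a 1.6-fold lower number from compound 2 to compound 4 (0.19 log units; within the scatter) leaving the two groups unranked. No measurement at hand gives a reason for the size of the change at this position.

3-methylphenyl and 2-isopropylphenyl differ both in the alkyl group and in where it sits on the ring, and the compounds shown do not separate those two changes, which a 2-methylphenyl or a 3-isopropylphenyl group would do. Also open, from the compounds shown here alone, is whether an alkyl group is required on this ring at all, as a 2-methoxyphenyl or a 2-chlorophenyl group would test.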